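A ring-for-ring swap on the arm of compound 3

The compounds below may be only part of what the source reports. "The series", "measured", "known", "first", "only" and "open" are said of these compounds alone.

For the measured compounds named here, in a functional assay on HeLa cells (Homo sapiens) for inhibition, with a stated time of 72 h (on this read-out lower numbers stand for stronger inhibition and higher numbers for weaker inhibition), compound 3 `NC1CCC(Nc2nc(NCc3ccc(-n4cccn4)cc3)c3ncn(C4CCCC4)c3n2)CC1` gives 170 nM and sits in the middle of the three numbers so far. Bromo-bearing compound 1 `NC1CCC(Nc2nc(NCc3ccc(Br)cc3)c3ncn(C4CCCC4)c3n2)CC1` gives 1510 nM and furan-2-yl-bearing compound 2 `NC1CCC(Nc2nc(NCc3ccc(-c4ccco4)cc3)c3ncn(C4CCCC4)c3n2)CC1` gives 71 nM at the low end. Compound 4 `NC1CCC(Nc2nc(NCc3ccc(-c4ccccc4)nc3)c3ncn(C4CCCC4)c3n2)CC1` brings one swap 6-phenylpyridin-3-yl in place of 4-(1H-pyrazol-1-yl)phenyl on a saturated chain carbon bound to a nitrogen on an aromatic ring in which 6-phenylpyridin-3-yl replaces 4-(1H-pyrazol-1-yl)phenyl on a saturated chain carbon bound to a nitrogen on an aromatic ring. Replacing bromo with a ring gave a 21-fold lower number from compound 1 to compound 2 (1.33 log units; beyond the scatter) and an 8.9-fold lower number from compound 1 to compound 3 (0.95 log units; beyond the scatter) whereas exchanging one ring for another gave the smaller 2.4-fold higher number from compound 2 to compound 3 (0.38 log units; beyond the scatter) and that smaller step is the closest guide here. The expected result in this assay is therefore a small move of no clear direction, estimated as a 1.1-fold lower number from compound 3 to compound 4 (0.05 log units; within the scatter) and probably within the scatter. Compound 4 is estimated at 150 nM with an expected range of 45 nM to 500 nM around it.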

Compound 4, half-maximal inhibitory concentration: 114 nM
Compound 4: middle estimate off by 1.3-fold (0.12 log units), on the high side, within the range that was stated.
By their numbers in this assay, from the lowest: compounds 2, 4 and 3 (each within the scatter of the next, the first and the last beyond it); then compound 1.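

In this assay, changing the whole two-ring arm, not only its outer ring, gives a 1.5-fold lower number from compound 3 to compound 4 (0.17 log units; within the scatter) and a 1.6-fold higher number from compound 2 to compound 4 (0.21 log units; within the scatter), so at this position a 6-phenylpyridin-3-yl serves about as well as the two arms ending in a five-membered ring. The advantage over the bromo arm also holds for this larger swap, with a 13-fold lower number from compound 1 to compound 4 (1.12 log units; beyond the scatter) and no sign of being lost. No measurement here gives a reason for these numbers.

On these data alone, it remains open whether a carboxylic acid or an amine on the outer ring would fit equally well. A longer chain between the ring and the nitrogen is also untested by the compounds shown.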